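Dihydroxymethyl analogue of the small fused core

A few compounds are considered here, and "the series" means these few. Any claim that something is new, unique, unknown or untested is made for them only; others in the source may bear on it.

Among the measured compounds shown here, the two measured members differ widely in size. Compound 1 `Cc1c(COC(=O)NCc2ccccc2)cc2n1[C@@H](c1ccccc1)SC2` carries a benzyl carbamate and a phenyl substituent on the shared core; in a functional assay on MCF7 cells (Homo sapiens) for cytotoxicity, read by MTT assay, with a stated time of 24 h (a higher number here means a weaker inhibitor, a lower number a stronger inhibitor), compound 1 gives 8800 nM. Compound 2 `Cc1c(CO)cc2n1CSC2` is the bare core with a single hydroxymethyl group, and in this assay compound 2 gives 186000 nM, the highest of the two numbers; its gap to compound 1 lies well beyond the scatter. No pair differing in a single place has been measured, so no single substituent effect can be read from the numbers shown.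

Compound 3 `Cc1c(CO)c(CO)c2n1CSC2` is the next candidate for this assay. Relative to compound 2 the change is hydroxymethyl in place of hydrogen on an aromatic carbon. For the measured compounds named here, there is no measured precedent for this kind of addition on the core. A second hydroxymethyl group is expected to move the number little; the step of a 1.2-fold lower number from compound 2 to compound 3 (0.09 log units; within the scatter) is estimated to stay within the scatter, with no clear direction. For compound 3 the expected value in this assay is 150000 nM, with a range from 50000 nM to 450000 nM.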

Compound 3, half-maximal inhibitory concentration: 37800 nM
The estimate for compound 3 lay 4.0-fold (0.60 log units) above the measured number; the whole stated range lies above it.
By their numbers in this assay, from the lowest: compound 1; then compound 3; then compound 2.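

Among the compounds shown here, the aromatic carbon two ring bonds from the ring nitrogen, which bears hydrogen in compound 2, is the first place on the shared core with a measured single-place step: in this assay, hydroxymethyl in place of hydrogen gives a 4.9-fold lower number from compound 2 to compound 3 (0.69 log units; beyond the scatter), a modest change beyond the scatter. This shows that the number in this assay responds to a change at this aromatic carbon, which the earlier pair of compounds, differing in more than one place, could not show. No measurement at hand bears on what lies behind this step.

Still open, on these data alone, is whether the step belongs to hydroxymethyl specifically or would also follow from another group on this carbon, such as a methyl group, an amine, a carboxylic acid or a longer chain ending in a hydroxyl group. Equally open, as far as these compounds go, is whether the same addition would give a comparable step on the more elaborate compound 1, which carries the benzyl carbamate and phenyl substituent and has hydrogen on this carbon.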